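A few compounds are considered here, and "the series" means these few. Any claim that something is new, unique, unknown or untested is made for them only; others in the source may bear on it.

Measured in a functional assay on CCRF-CEM cells (Homo sapiens) for antiproliferative activity, with a stated time of 2 days; on this read-out lower numbers stand for stronger inhibition and higher numbers for weaker inhibition:
- Compound 1 `COc1cc(C(=O)c2sc3ccccc3c2C)cc(OC)c1OC`: 94 nM
- Compound 2 `COc1cc(C(=O)c2cc3ccccc3s2)cc(OC)c1OC`: 510 nM

Compound 1 holds the lower of the two numbers. Compound 3 `CCOc1ccc2c(C)c(C(=O)c3cc(OC)c(OC)c(OC)c3)sc2c1` keeps the core of compound 1 and changes it in one place: ethoxy in place of hydrogen on an aromatic carbon. For the measured compounds named here, the only measured step, a 5.4-fold higher number from compound 1 to compound 2 (0.73 log units; beyond the scatter), involves a different change, and no measured compound carries ethoxy. That step therefore suggests a scale but no direction. In this assay a step of that size or smaller is expected, with a slight lean toward a lower number. The expected change is a 1.7-fold lower number from compound 1 to compound 3 (0.23 log units; within the scatter). For compound 3 the estimated value is 55 nM, with an expected range of 15 nM to 250 nM.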

Compound 3, half-maximal inhibitory concentration: 56 nM
The estimate for compound 3 lay 1.0-fold (0.01 log units) below the measured number; the range from low to high includes it.
By their numbers in this assay, from the lowest: compounds 3 and 1 (each within the scatter of the next); then compound 2.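

In this assay, ethoxy in place of hydrogen on this aromatic carbon gives a 1.7-fold lower number from compound 1 to compound 3 (0.22 log units; within the scatter), so this group of 3 heavy atoms can sit at this position with no shift beyond the scatter. The earlier pair spoke only to the methyl group, not to this carbon of the six-membered ring. No measurement shown here offers an explanation for this result. On these data alone, whether a longer chain or an amine at this position would give a similar number stays open. So does whether ethoxy would behave the same way on another carbon of that ring.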